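Oxadiazole aryl swaps on a methylsulfonylphenyl core

The compounds below may be only part of what the source reports. "The series", "measured", "known", "first", "only" and "open" are said of these compounds alone.

The series shares one core and varies only the ring on the five-membered aromatic ring with two nitrogen and one oxygen. Compound 1 `CS(=O)(=O)c1ccc(-c2cnc3[nH]cc(-c4nnc(-c5ccncc5)o4)c(=O)c3c2)cc1` gives 7.83% in a functional assay on HCT-116 cells (Homo sapiens) for inhibition, read by MTT assay, with a stated time of 24 h, tested at 10 uM; a higher number here means more inhibition of growth at the concentration tested, a lower number less inhibition of growth. Compound 2 `CS(=O)(=O)c1ccc(-c2cnc3[nH]cc(-c4nnc(-c5ccccc5)o4)c(=O)c3c2)cc1` gives 15.7% in this assay. Compound 3 `CS(=O)(=O)c1ccc(-c2cnc3[nH]cc(-c4nnc(-c5ccccn5)o4)c(=O)c3c2)cc1` gives 16.2% in this assay, which puts compound 3 at the upper end of three numbers that all lie within the scatter of one another: a number 8.4 percentage points higher from compound 1 to compound 3 (within the scatter), a number 0.5 percentage points higher from compound 2 to compound 3 (within the scatter), and a number 7.9 percentage points higher from compound 1 to compound 2 (within the scatter).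

Compound 4 `Cc1ccc(-c2nnc(-c3c[nH]c4ncc(-c5ccc(S(C)(=O)=O)cc5)cc4c3=O)o2)cc1` is not yet measured. It differs from compound 3 in one place: 4-methylphenyl in place of pyridin-2-yl on an aromatic carbon.

For the measured compounds named here, two measured steps bear on this change. The step from compound 2 to compound 3, a number 0.5 percentage points higher from compound 2 to compound 3 (within the scatter), shows that a pyridin-2-yl and a phenyl at this position give numbers within the scatter. The step from compound 1 to compound 2, a number 7.9 percentage points higher from compound 1 to compound 2 (within the scatter), also stays within the scatter. With every swap of the ring on this carbon so far within the scatter, no step beyond the scatter is expected in this assay for compound 4 either, in either direction; the expected step is a number 2.2 percentage points lower from compound 3 to compound 4 (within the scatter). Compound 4 is therefore estimated at 14%, with a range of 4% to 25%.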

Compound 4, percent growth inhibition at one concentration: 24.4%
Compound 4: middle estimate off by 10.4 percentage points, on the low side; the measured number falls inside the stated range.
By their numbers in this assay, from the lowest: compounds 1, 2, 3 and 4 (each within the scatter of the next, the first and the last beyond it).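

For the compounds shown here, only one pair at this position now separates beyond the scatter: 4-methylphenyl in place of pyridin-4-yl gives a modest step in this assay (a number 16.6 percentage points higher from compound 1 to compound 4 (beyond the scatter)). Neither adjacent comparison separates on its own: methyl in place of hydrogen on the phenyl ring gives one step (a number 8.7 percentage points higher from compound 2 to compound 4 (within the scatter)) and 4-methylphenyl in place of pyridin-2-yl gives another (a number 8.2 percentage points higher from compound 3 to compound 4 (within the scatter)), so compound 2 and compound 3 remain within the scatter of both ends of the series and the methyl alone cannot be credited with a real change. Nothing available for these compounds accounts for the separation between the two end members of the series.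

As far as these compounds go, it remains open whether an amine, a carboxylic acid or a longer chain in place of the methyl of compound 4 would separate from compound 4 in this assay. From the compounds shown here alone, it also remains open whether any ring on this carbon of the five-membered aromatic ring can give a step larger than the modest one seen here, or whether the spread across this position stays this narrow.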